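This account rests on a few compounds, and the source may have more. Where it says the series, first, only, none or still open, it means among the compounds named here.

Measured in a functional assay on MDA-MB-435 cells (Homo sapiens) for inhibition; a lower number here means a stronger inhibitor of growth, a higher number a weaker inhibitor of growth:

- Compound 1 `NC(=O)c1cc(Cl)ccc1NC(=O)COc1ccccc1`: 356 nM
- Compound 2 `NC(=O)c1cc(I)ccc1NC(=O)COc1ccccc1`: 101 nM

Of these two, compound 2 has the lower number, so it is the stronger inhibitor of growth so far. Going by the values given here, the only measured step runs a 3.5-fold lower number from compound 1 to compound 2 (0.55 log units; beyond the scatter), and it came from placing iodo where chloro stood on an aromatic carbon.

Compound 3 `COc1ccc(NC(=O)COc2ccccc2)c(C(N)=O)c1` keeps the shared core and changes that same carbon again: methoxy in place of iodo on an aromatic carbon. In words, methoxy takes the place of iodo. Among the compounds with values here, the step to compound 2 is the only evidence that bears on this change. Within the data shown here, it shows that the number in this assay responds to the group at this carbon, but no measured compound carries methoxy, so the direction remains a judgement. Losing the iodo of compound 2 at 101 nM suggests a move back towards compound 1 at 356 nM, by a step of similar modest size.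

The expected change is a 3.5-fold higher number from compound 2 to compound 3 (0.54 log units; beyond the scatter), which is an estimate only. For compound 3 the estimated value is 350 nM, with an expected range of 100 nM to 1200 nM.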

Compound 3, concentration for 50% growth inhibition: 121 nM
Beside the measured number, compound 3's estimate is 2.9-fold (0.46 log units) above it; measured number inside the range.
By their numbers in this assay, from the lowest: compounds 2 and 3 (each within the scatter of the next); then compound 1.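

In this assay, putting methoxy in place of iodo gives a 1.2-fold higher number from compound 2 to compound 3 (0.08 log units; within the scatter), so at this carbon, para to a large group, the two groups cannot be told apart. The earlier step could have been read as something special to iodo. Yet methoxy, which brings a carbon and an oxygen and one hydrogen-bond acceptor where iodo brought a single heavy atom and none, also stands clear of chloro, with a 2.9-fold lower number from compound 1 to compound 3 (0.47 log units; beyond the scatter). Going by these compounds alone, the result therefore ties the lower numbers to more than one kind of group, although with only three compounds this is no rule, and nothing measured here says why methoxy and iodo match while chloro differs.

The compounds shown leave open whether a longer chain such as ethoxy, an amine or a carboxylic acid at this carbon would keep the number near that of compound 2 or compound 3, or move it towards that of compound 1. The rest of the shared core stays the same throughout, so they also leave open whether this match between methoxy and iodo would hold if another part of the molecule were changed.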